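Removing the Cyclopropyl Group from the Amide Nitrogen

The source may report more compounds than this note shows. Statements on the series, on what has been measured and on what is new or still open speak of the compounds shown alone.

Of the compounds shown here, three sharing one core have been tested in a functional assay on the whole organism with Mus musculus as the target, in the rotarod test; a lower number here means that less compound is needed, a higher number that more compound is needed for the effect. Compound 1 `O=C(/C=C1\CCc2cc(F)cc(F)c21)NC1CC1` gives 81 mg/kg. Compound 2 `NC(=O)/C=C1\CCc2cc(F)cc(F)c21` gives 81 mg/kg, and compound 3 `O=C(/C=C1\CCc2cc(F)ccc21)NC1CC1` gives 193 mg/kg.

Two single changes link them. Going from compound 1 to compound 2, the change is hydrogen in place of cyclopropyl on an amide-type nitrogen, and the outcome is no change at the digits printed from compound 1 to compound 2 (within the scatter). Going from compound 1 to compound 3, the change is hydrogen in place of fluoro on an aromatic carbon, and the outcome is a 2.4-fold higher number from compound 1 to compound 3 (0.38 log units; beyond the scatter).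

Compound 4 `NC(=O)/C=C1\CCc2cc(F)ccc21` has not yet been measured. It differs from compound 3 by hydrogen in place of cyclopropyl on an amide-type nitrogen, the same change that separates compound 1 from compound 2, made here on the core of compound 3 rather than that of compound 1; the two cores differ as described by hydrogen in place of fluoro on an aromatic carbon.

For this assay the step is expected to be no change at the digits printed from compound 3 to compound 4 (within the scatter), because no change at the digits printed from compound 1 to compound 2 (within the scatter) shows that this change left the dose essentially unaltered. Compound 4 is therefore estimated to need 193 mg/kg. The plausible range for compound 4 is estimated to run from 100 mg/kg to 370 mg/kg.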

Compound 4, dose for half-maximal effect: > 100 mg/kg
Compound 4: no number, only a limit; the forecaster's own chance of this, stated with the estimate: 10%; the middle value lies beyond the limit too.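

In this assay compound 4 gives only a limit, > 100 mg/kg, and not a number. The swap of cyclopropyl for hydrogen on the amide nitrogen cannot be read on the core of compound 3, so this result neither confirms nor contradicts what the same swap did on the core of compound 1. Losing the fluoro group can be followed on the amide without cyclopropyl, where it gives an at least 1.2-fold higher number from compound 2 to compound 4 (0.09 log units; that floor lies within the scatter), but this is only a floor, and the comparison with the other core stays unsettled: the same change on two cores in this assay, a 2.4-fold higher number (0.38 log units; beyond the scatter) from compound 1 to compound 3 and an at least 1.2-fold higher number (0.09 log units; that floor lies within the scatter) from compound 2 to compound 4; the limit leaves it open whether they differ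

The compounds shown leave open whether the swap to hydrogen behaves on the core of compound 3 as it does on the core of compound 1, which only a number for compound 4 could settle. They also leave open what a methyl group on the amide nitrogen, or a chloro group in place of fluoro on an aromatic carbon, would do in this assay.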